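Acetyl to dimethylamino on a distal phenyl ring

A few compounds are considered here, and "the series" means these few. Any claim that something is new, unique, unknown or untested is made for them only; others in the source may bear on it.

Compound 1 `COc1cc(C)cc(-c2c(-c3ccnc(-c4ccc(C(C)=O)cc4)c3)cnn2CC#N)c1`: 4%
Compound 2 `Cc1cc(O)cc(-c2nn(CC#N)cc2-c2ccnc(-c3ccc(Oc4ccccc4)cc3)c2)c1`: -13%

In a functional assay on K562 cells (Homo sapiens) for cytotoxicity, read by sulforhodamine B assay, with a stated time of 48 h, tested at 1 uM (a lower number here means a stronger effect, a higher number a weaker effect of the compound at the concentration tested), compound 1 gives 4%, the higher of the two numbers recorded; compound 2 gives -13%, a gap beyond the usual scatter. Compound 3 `COc1cc(C)cc(-c2c(-c3ccnc(-c4ccc(N(C)C)cc4)c3)cnn2CC#N)c1` has not been measured. It differs from compound 1 by dimethylamino in place of acetyl on an aromatic carbon. For the measured compounds named here, no step between measured compounds isolates this change, and both recorded numbers sit near zero, so the authors expect no step beyond the scatter: the estimated change a number 2 percentage points lower from compound 1 to compound 3 (within the scatter) is small. Compound 3 is expected to give about 2%, between -13% and 17%.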

Compound 3, a percentage reported as activity, at one concentration (the size of the read-out at that concentration, not a potency): -5%
Compound 3: middle estimate off by 7 percentage points, on the high side; measured number inside the range.
By their numbers in this assay, from the lowest: compounds 2, 3 and 1 (each within the scatter of the next, the first and the last beyond it).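

For the compounds shown here, on the six-membered aromatic ring, at the carbon para to a large group, this is the first exchange that can be read on its own: 4-acetylphenyl to 4-(dimethylamino)phenyl gives a number 9 percentage points lower from compound 1 to compound 3 (within the scatter) in this assay. At this one concentration, the position therefore accepts dimethylamino in place of acetyl without a step beyond the scatter, although this single pair shows no trend.

On these data alone, it remains open whether a carboxylic acid, a primary amine or a longer alkyl chain at this position would shift the read-out beyond the scatter, and whether the two compounds would differ in the strength of their effect at other concentrations. Nothing available explains the result.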